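The source may report more compounds than this note shows. Statements on the series, on what has been measured and on what is new or still open speak of the compounds shown alone.

Of the compounds shown here, three sharing one core have been measured so far in a functional assay on LoVo cells (Homo sapiens) for cytotoxicity, read by MTT assay (a lower number here means a stronger inhibitor, a higher number a weaker inhibitor), as a test of how strongly they act on these cells. Compound 1 (`Oc1ccc(CN(Cc2ccccc2C(F)(F)F)Cc2ccc(O)c3ncccc23)c2cccnc12`) gives 93 nM as the highest number of the three, which makes it the weakest inhibitor in this small set. Compound 3 (`Oc1ccc(CN(Cc2cccs2)Cc2ccc(O)c3ncccc23)c2cccnc12`) gives 40 nM and compound 2 (`Oc1ccc(CN(Cc2cc(C(F)(F)F)cc(C(F)(F)F)c2)Cc2ccc(O)c3ncccc23)c2cccnc12`) gives 10 nM as the lowest number.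

Compound 4 (`O=C(O)C1CCC(CN(Cc2ccc(O)c3ncccc23)Cc2ccc(O)c3ncccc23)CC1`) is still unmeasured. It keeps the core of compound 1 but carries 4-carboxycyclohexyl in place of 2-(trifluoromethyl)phenyl on a saturated chain carbon bound to an amine nitrogen.

Among the measured compounds shown here, one measured step bears directly on this place: thiophen-2-yl in place of 2-(trifluoromethyl)phenyl gave a 2.3-fold lower number from compound 1 to compound 3 (0.37 log units; beyond the scatter) and counts as modest. Compound 2 also has a different group at that place, and its value lies further from that of compound 1. None of the three measured compounds holds a non-aromatic ring or a carboxy group there, and the direction of the change cannot be read from them.

No clear step beyond the scatter is expected in this assay although a slightly higher number seems more likely than a lower one. The estimated step is a 1.4-fold higher number from compound 1 to compound 4 (0.15 log units; within the scatter) and it remains uncertain. Compound 4 is expected at 130 nM within an estimated range of 30 nM to 550 nM as the likely span.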

Compound 4, half-maximal inhibitory concentration: 422 nM
Compound 4: the middle estimate sits 3.2-fold (0.51 log units) below what was measured; the measured number falls inside the stated range.
By their numbers in this assay, from the lowest: compound 2; then compound 3; then compound 1; then compound 4.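

In this assay, this place on a saturated chain carbon bound to an amine nitrogen now shows changes in both directions relative to compound 1. The one earlier step listed here went down, whereas 4-carboxycyclohexyl in place of 2-(trifluoromethyl)phenyl moves the number up (a 4.5-fold higher number from compound 1 to compound 4 (0.66 log units; beyond the scatter)), so a new group at this place can also cost activity on these cells. The same group in place of thiophen-2-yl gives a large step (an 11-fold higher number from compound 3 to compound 4 (1.02 log units; beyond the scatter)), which shows how much the outcome depends on the group chosen here, though no evidence at hand gives a reason for either step.

Compound 4 brings in a non-aromatic ring and a carboxy group at once, so the compounds shown leave open which of the two goes with the higher number. A plain cyclohexyl group would test the ring without the carboxylic acid, and a phenyl ring carrying a carboxylic acid would test the acid on an aromatic ring.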